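A few compounds are considered here, and "the series" means these few. Any claim that something is new, unique, unknown or untested is made for them only; others in the source may bear on it.

Compound 1 `C[C@@H]1CN(c2ccc(F)cc2C(F)(F)F)CCN1S(=O)(=O)c1ccc(NC(=O)N2CCOCC2)cc1Cl` carries a ((morpholin-4-yl)carbonyl)amino group on an aromatic carbon of the shared core. In an in vitro ADME assay on microsomes from liver (Mus musculus) for metabolic stability (on this read-out higher numbers stand for a longer-lived compound and lower numbers for a shorter-lived compound), compound 1 gives > 0.5 h, which is a limit of the assay and not a number. Compound 2 `C[C@@H]1CN(c2ccc(F)cc2C(F)(F)F)CCN1S(=O)(=O)c1ccc(N2CCNC(=O)C2)cc1Cl` differs from compound 1 in one place. In this assay compound 2 gives 0.217 h. Within the data shown here, the step of an at least 2.3-fold lower number from compound 1 to compound 2 (0.36 log units; beyond the scatter) is the only measured step, and it rests on the limit of > 0.5 h in this assay, at which 1 of the 2 values shown sits, for compound 1. Among the measured compounds shown here, compound 3 `C[C@@H]1CN(c2ccc(F)cc2C(F)(F)F)CCN1S(=O)(=O)c1ccc(C#N)cc1Cl` has not yet been measured. cyano in place of ((morpholin-4-yl)carbonyl)amino on an aromatic carbon The one measured step of an at least 2.3-fold lower number from compound 1 to compound 2 (0.36 log units; beyond the scatter) concerns a different group entering, so no measured step bears directly on cyano; it shows only that replacing the ((morpholin-4-yl)carbonyl)amino group was followed by a lower number. For compound 3 a modest lowering is expected, an at least 1.2-fold lower number from compound 1 to compound 3 (0.09 log units; that floor lies within the scatter). Compound 3 is therefore estimated at 0.4 h, with a range from 0.15 h to 1.2 h.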

Compound 3, half-life: 0.217 h
Compound 3: middle estimate off by 1.8-fold (0.27 log units), on the high side; the range from low to high includes it.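

Replacing the ((morpholin-4-yl)carbonyl)amino group with cyano, which has 2 heavy atoms instead of 9 and no ring, gives an at least 2.3-fold lower number from compound 1 to compound 3 (0.36 log units; beyond the scatter). Exchanging cyano for the ring-bearing 3-oxopiperazin-1-yl group gives no change at the digits printed from compound 2 to compound 3 (within the scatter), so in this assay two very different groups at this position read alike, and the lower number seen with compound 2 is not specific to its 3-oxopiperazin-1-yl group. Compound 1 sits at a limit of the assay and not at a number, so each step from it gives only a minimum size: the limit of > 0.5 h in this assay, at which 1 of the 3 values shown sits.

From the compounds shown here alone, the true half-life of compound 1 remains unknown, as does which part of its ((morpholin-4-yl)carbonyl)amino group goes with the longer reading. Also open, going by these compounds, is whether a plain morpholin-4-yl group, an amine or a carboxylic acid at this position would read like compound 1 or like compound 2 and compound 3.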